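The source may report more compounds than this note shows. Statements on the series, on what has been measured and on what is new or still open speak of the compounds shown alone.

Compounds measured so far:

Compound 1 `N#CC1=C(N)Oc2c(c3nc4ccccc4nc3c3ccccc23)C12C(=O)N(Cc1cnnn1-c1ccccc1Cl)c1ccccc12` gives in a functional assay on HepG2 cells (Homo sapiens) for antiproliferative activity, read by MTT assay, with a stated time of 48 h (a higher number here means a weaker inhibitor, a lower number a stronger inhibitor), only a limit, > 50000 nM.
Compound 2 `N#CC1=C(N)Oc2c(c3nc4ccccc4nc3c3ccccc23)C12C(=O)N(Cc1cnnn1-c1cccc(Br)c1)c1ccccc12` gives in this assay only a limit, > 50000 nM.
Compound 3 `Cc1ccc(C)c(-n2nncc2CN2C(=O)C3(C(C#N)=C(N)Oc4c3c3nc5ccccc5nc3c3ccccc43)c3ccccc32)c1` gives in this assay only a limit, > 50000 nM.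

Compound 2 therefore stands at the limit of this assay, as do the other two members of the series, since all values reported so far sit at that limit (the limit of > 50000 nM in this assay, at which 3 of the 3 values shown sit). Among the compounds with values here, no compound in the set has yet returned a number.

The next compound, compound 4 `Cc1ccc(-n2nncc2CN2C(=O)C3(C(C#N)=C(N)Oc4c3c3nc5ccccc5nc3c3ccccc43)c3ccccc32)c(C)c1`, changes the aryl group on the triazole nitrogen of compound 2: 2,4-dimethylphenyl in place of 3-bromophenyl on an aromatic nitrogen.

The steps already measured that touch the same position are a step that the two limits leave unreadable from compound 1 to compound 2, a step that the two limits leave unreadable from compound 1 to compound 3 and a step that the two limits leave unreadable from compound 2 to compound 3. None of them can be read, since both ends of each pair are limits. The closest analogue, compound 3 with its 2,5-dimethylphenyl, likewise sits at the limit. No readable step is available from which a direction or size could be taken for this assay.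

The expectation is that compound 4 remains at or beyond the limit of this assay. The step is expected as a step that the limit leaves unreadable from compound 2 to compound 4. Compound 4 is estimated at 70000 nM, with a range from 25000 nM to 250000 nM.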

Compound 4, half-maximal inhibitory concentration: > 50000 nM
Compound 4 gave a limit, no number; the forecaster's own chance of this, stated with the estimate: 85%; the middle value lies beyond the limit too.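

Compound 4 joins compound 1, compound 2 and compound 3 at a limit, so no step among these compounds can be read: the limit of > 50000 nM in this assay, at which 4 of the 4 values shown sit.

Going by these compounds, whether any aryl group on this aromatic nitrogen gives a measurable value in this assay, and how such groups would rank, remains open.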